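Chain-end exchange: sulfo replaced by piperidin-1-yl

The compounds below may be only part of what the source reports. "The series", "measured", "known", "first", "only" and "open" are said of these compounds alone.

Of the compounds shown here, three sharing one core have been measured in an assay on HEK293 cells for displacement of a labelled ligand from 5-hydroxytryptamine receptor 4 (Homo sapiens), read by scintillation counting; a lower number here means a stronger inhibitor, a higher number a weaker inhibitor. Compound 1 `COc1cc(N)c(Cl)cc1C(=O)NC1CCN(CCCCCO)CC1` gives 63.1 nM, and compound 2 `COc1cc(N)c(Cl)cc1C(=O)NC1CCN(CCCCCN2C(=O)c3ccccc3C2=O)CC1` gives 20 nM. Compound 3 `COc1cc(N)c(Cl)cc1C(=O)NC1CCN(CCCCCCCCS(=O)(=O)O)CC1` gives 15800 nM, the highest number of the three; the step is a 250-fold higher number from compound 1 to compound 3 (2.40 log units; beyond the scatter) and a 790-fold higher number from compound 2 to compound 3 (2.90 log units; beyond the scatter), both well beyond the scatter, so compound 3 is the weakest of the measured set.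

Compound 4 `COc1cc(N)c(Cl)cc1C(=O)NC1CCN(CCCCCCCCN2CCCCC2)CC1` has not yet been measured in this assay. It differs from compound 3 by piperidin-1-yl in place of sulfo on a saturated chain carbon, eight bonds along the chain from an amine nitrogen in a ring. Both measured steps into compound 3 bear on this exchange: introducing the sulfo-bearing chain end in place of hydroxy, or in place of the ring-bearing group of compound 2, produced large rises in the number. Removing the sulfo group is therefore expected to reverse most of that loss, and the entering piperidin-1-yl resembles the ring-bearing chain end of compound 2, which in this assay gives 20 nM. A large step downward is expected, a 530-fold lower number from compound 3 to compound 4 (2.72 log units; beyond the scatter), with the longer chain of compound 4 leaving the exact landing point uncertain. Compound 4 is estimated at 30 nM, within a range of 8 nM to 150 nM.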

Compound 4, inhibition constant: 3.16 nM
Beside the measured number, compound 4's estimate is 9.5-fold (0.98 log units) above it; the whole stated range lies above it.
By their numbers in this assay, from the lowest: compound 4; then compound 2; then compound 1; then compound 3.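

Working notes on the chain end: in this assay, the exchange at this place, eight bonds along the chain from an amine nitrogen in a ring, gives the widest span in the series, with a 5000-fold lower number from compound 3 to compound 4 (3.70 log units; beyond the scatter). For the compounds shown here, until now the long chain was seen only with sulfo at its end, so its weak number could have belonged to the chain, yet compound 4 carries a chain of the same length and is the strongest inhibitor of the four, which places the loss with the sulfo end and not with chain length alone. The ring-bearing end also goes past both shorter-chain compounds, with a 6.3-fold lower number from compound 2 to compound 4 (0.80 log units; beyond the scatter) and a 20-fold lower number from compound 1 to compound 4 (1.30 log units; beyond the scatter), so the long chain is compatible with the lowest number in the series. No measurement at hand accounts for the size of these steps.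

Going by these compounds, how much of the gain belongs to chain length and how much to piperidin-1-yl stays open: compound 1 and compound 2 sit on the shorter chain, compound 3 and compound 4 on the longer, and each comparison across that divide also changes the chain end. Also open, on these data alone, is how specific the result is to piperidin-1-yl, which a cyclohexyl, a morpholin-4-yl, a carboxylic acid or a still longer chain at this place would help to settle.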